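A pyridin-2-yl group on the sulfonamide nitrogen

The compounds below may be only part of what the source reports. "The series", "measured", "known", "first", "only" and "open" are said of these compounds alone.

In a functional assay on MDA-MB-435 cells (Homo sapiens) for antiproliferative activity, read by sulforhodamine B assay, with a stated time of 72 h (on this read-out higher numbers stand for weaker inhibition and lower numbers for stronger inhibition), compound 1 (`O=S(=O)(Nc1ncccn1)c1ccc(Nc2nncc3ccccc23)cc1`) gives 45 nM and compound 2 (`O=S(=O)(Nc1nccs1)c1ccc(Nc2nncc3ccccc23)cc1`) gives 36 nM. These two values lie within the scatter of each other, so compound 2 cannot be separated from compound 1 on these numbers. Compound 3 (`O=S(=O)(Nc1ccccn1)c1ccc(Nc2nncc3ccccc23)cc1`) has pyridin-2-yl in place of 1,3-thiazol-2-yl on a sulfonamide nitrogen. Among the compounds with values here, one measured step bears on this change, the exchange of pyrimidin-2-yl for 1,3-thiazol-2-yl at that nitrogen, which gave a 1.3-fold lower number from compound 1 to compound 2 (0.10 log units; within the scatter). Within the data shown here, no measured compound yet shows a step beyond the scatter at this place, so none is expected here. The expected step is a 1.3-fold higher number from compound 2 to compound 3 (0.10 log units; within the scatter), which stays within the scatter. The estimated value for compound 3 is 45 nM, with an expected range of 20 nM to 100 nM.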

Compound 3, half-maximal inhibitory concentration: 36 nM
Estimate against measurement, compound 3: 1.3-fold (0.10 log units) above; the measured number falls inside the stated range.
By their numbers in this assay, from the lowest: compounds 2, 3 and 1 (each within the scatter of the next).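

Pyridin-2-yl on the sulfonamide nitrogen adds a third aromatic ring to this place, and in this assay the exchange for 1,3-thiazol-2-yl gives no change at the digits printed from compound 2 to compound 3 (within the scatter), while the exchange for pyrimidin-2-yl gives a 1.3-fold lower number from compound 1 to compound 3 (0.10 log units; within the scatter). All three groups therefore remain inseparable on these numbers, so this set of compounds now shows that a one-hetero-atom six-membered aromatic ring can stand here without a step beyond the scatter. Nothing available explains why these exchanges leave the read-out within the scatter.

All the groups shown at this nitrogen are aromatic rings, so the compounds leave open what a saturated ring such as piperidin-4-yl, a short chain such as methyl, or a bare sulfonamide hydrogen would do. They also leave open whether a carboxylic acid or an amine on the pyridin-2-yl ring would keep the value within this range.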